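Pyrazole ring methyl removal in a lipase inhibitor series

The compounds below may be only part of what the source reports. "The series", "measured", "known", "first", "only" and "open" are said of these compounds alone.

Measured so far in an assay on membranes from brain for binding affinity to Monoglyceride lipase (Mus musculus), read by fluorescence, with stated times of 1 h and 30 min; a lower number here means a stronger inhibitor, a higher number a weaker inhibitor:
compound 1 `Cc1cnn(C(=O)NCc2ccc(OCc3ccccc3)cc2)c1` gives 1000 nM
compound 2 `O=C(NCc1ccc(OCc2ccccc2)cc1)n1cccn1` gives 900 nM
compound 3 `Cc1cnn(C(=O)N2CCN(C(c3ccc(OCc4ccccc4)cc3)c3ccc(OCc4ccccc4)cc3)CC2)c1` gives 2100 nM

Compound 1 and compound 2 differ by hydrogen in place of methyl on an aromatic carbon, and this gave a 1.1-fold lower number from compound 1 to compound 2 (0.05 log units; within the scatter). Compound 3 carries a different core; the difference between the two cores is not broken down here, and compound 3 shows the highest number of the three in this assay. Compound 4 `O=C(N1CCN(C(c2ccc(OCc3ccccc3)cc2)c2ccc(OCc3ccccc3)cc2)CC1)n1cccn1` is not yet measured; it differs from compound 3 by hydrogen in place of methyl on an aromatic carbon, at the same place as in the earlier pair, so this is the same change made once more on the other core. The step from compound 3 to compound 4 in this assay is expected to be a 1.1-fold lower number from compound 3 to compound 4 (0.04 log units; within the scatter), because compound 1 to compound 2 gave a 1.1-fold lower number from compound 1 to compound 2 (0.05 log units; within the scatter). Compound 4 is therefore estimated at 1900 nM, between 900 nM and 4000 nM.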

Compound 4, half-maximal inhibitory concentration: 3900 nM
Beside the measured number, compound 4's estimate is 2.1-fold (0.31 log units) below it, and the stated range covers the measured number.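

In this assay, the change from 4-methyl-1H-pyrazol-1-yl to 1H-pyrazol-1-yl on the core of compound 3 gives a 1.9-fold higher number from compound 3 to compound 4 (0.27 log units; within the scatter), so neither core shows a step beyond the scatter. Set side by side, the two steps do not differ beyond what repeated measurements would allow: the same change on two cores in this assay, a 1.1-fold lower number (0.05 log units; within the scatter) from compound 1 to compound 2 and a 1.9-fold higher number (0.27 log units; within the scatter) from compound 3 to compound 4, 2.1-fold (0.31 log units) apart, within the scatter of two such steps. This is consistent with the change carrying across these two cores without a detectable effect, but two small steps in one assay establish neither a direction nor a size for it, and they do not show that the change is silent on other cores.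

Only methyl and hydrogen appear at this place on the ring. From the compounds shown here alone, whether a chlorine, a nitrile or a propyl chain there would produce a step beyond the scatter on either core remains open.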